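This account rests on a few compounds, and the source may have more. Where it says the series, first, only, none or still open, it means among the compounds named here.

Of the compounds shown here, three have so far been measured in an assay on cells with Cystic fibrosis transmembrane conductance regulator variant F508del (Homo sapiens) as the target, read by fluorescence, with stated times of 24 h and 30 min; a higher number here means that more compound is needed for the effect, a lower number that less compound is needed. Compound 1 `COc1ccc(Cl)cc1Cc1cc(-c2sc(NC(=O)C(C)(C)C)nc2C)nn1C(=O)NCCO` gives 3020 nM in this assay, and compound 3 `COc1ccc(NC(=O)n2nc(-c3sc(NC(=O)C(C)(C)C)nc3C)cc2Cc2cc(Cl)ccc2OC)cc1` gives 1000 nM. Among the compounds with values here, these two share a core and differ in a single place, so the step of a 3.0-fold lower number from compound 1 to compound 3 (0.48 log units; beyond the scatter) is the one direct comparison the measured set offers. Compound 2 `CC(=O)NCCCNc1nc(-c2ccccn2)nc2c1CN(Cc1ccc(F)cc1)CC2` is built on a different core, and in this assay compound 2 gives 200 nM, the lowest of the three numbers; compound 3 comes nearest to it and compound 1 lies furthest away, with both gaps beyond the scatter.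

Compound 4 `Fc1ccc(CN2CCc3nc(-c4ccccn4)nc(NCCCN4CCCC4)c3C2)cc1` differs from compound 2 in one place: pyrrolidin-1-yl in place of acetamido on a saturated chain carbon, three bonds along the chain from a nitrogen on an aromatic ring. Within the data shown here, no measured step bears on this change. Among the measured compounds shown here, the only step in hand, between compound 1 and compound 3, concerns another core and another group on an amide-type nitrogen, so it gives no direct guidance on exchanging acetamido for pyrrolidin-1-yl on the chain. With nothing pointing either way, the expectation is a number close to that of compound 2 and no step beyond the scatter. In this assay compound 4 is therefore expected to give about 200 nM, most likely between 50 nM and 800 nM. The step this estimate implies is expected to be no change at the digits printed from compound 2 to compound 4 (within the scatter).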

Compound 4, half-maximal effective concentration: 200 nM
Compound 4: middle estimate and measured number agree at the digits printed, and the stated range covers the measured number.
By their numbers in this assay, from the lowest: compounds 2 and 4 (each within the scatter of the next); then compound 3; then compound 1.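

In this assay, within the data shown here, the exchange gives no change at the digits printed from compound 2 to compound 4 (within the scatter), and this is the first direct comparison on the core of compound 2, as the earlier step belongs to another core and another place. On this core and at this place on a saturated chain carbon, three bonds along the chain from a nitrogen on an aromatic ring, two quite different groups therefore give numbers within the scatter of each other: acetamido, with 1 hydrogen-bond donor and a double bond outside aromatic rings, and pyrrolidin-1-yl, with 0 hydrogen-bond donors and one five-membered non-aromatic ring. No available evidence accounts for this match.

One pair cannot show whether the number stays the same for every group at this place, so a carboxylic acid, a hydroxyl or a piperidine ring at the end of the chain remains an open test. Also open, on these data alone, is how the number responds to a shorter or longer chain carrying either acetamido or pyrrolidin-1-yl, since both compounds share the same chain length.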